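Swapping the Cyclohexyl Ring for a Carbamate-Bearing Piperidine

The source may hold more compounds than are shown below. What is called first, only, known or untested is meant among the compounds shown, and "the series" means these compounds.

Compound 2 `O=C(Nc1ccc(S(=O)(=O)NC2CCCCC2)c2ccccc12)c1ccccc1` carries a cyclohexylamino group on the sulfonyl sulfur of the shared core. Among the compounds with values here, in an assay on L1.2 cells for binding affinity to C-C chemokine receptor type 8 (Homo sapiens) (a higher number here means a weaker inhibitor, a lower number a stronger inhibitor), compound 2 gives 4.4 nM, the only outright number in this small set. Compound 1 `O=C(Nc1ccc(S(=O)(=O)N2CCCCC2)c2ccccc12)c1ccccc1`, whose sulfonyl sulfur carries piperidin-1-yl instead, gives only a limit of the assay, > 30000 nM. Within the data shown here, the single measured step is therefore an at least 6800-fold lower number from compound 1 to compound 2 (3.83 log units; beyond the scatter), and its stated size comes from the limit of > 30000 nM in this assay, at which 1 of the 2 values shown sits; what it shows is that keeping a hydrogen on the sulfonamide nitrogen goes together with very strong binding.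

Compound 3 `CCOC(=O)N1CCC(NS(=O)(=O)c2ccc(NC(=O)c3ccccc3)c3ccccc23)CC1` keeps that hydrogen and alters only the ring attached to the nitrogen: 1-(ethoxycarbonyl)piperidin-4-yl in place of cyclohexyl on a sulfonamide nitrogen. Among the measured compounds shown here, no measured pair tests a change of this kind, so the step from compound 1 to compound 2 bears on it only indirectly, by indicating that the feature of compound 2 most clearly tied to binding is left untouched. In this assay a step of modest size is expected, possibly within the scatter, with a small loss somewhat more likely than a gain: a 2.0-fold higher number from compound 2 to compound 3 (0.31 log units; beyond the scatter). Compound 3 is estimated at 9 nM, with a likely range from 2.5 nM to 40 nM.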

Compound 3, inhibition constant: 0.17 nM
The estimate for compound 3 lay 53-fold (1.72 log units) above the measured number; the whole stated range lies above it.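

In this assay, putting 1-(ethoxycarbonyl)piperidin-4-yl in place of cyclohexyl on a sulfonamide nitrogen gives a 26-fold lower number from compound 2 to compound 3 (1.41 log units; beyond the scatter), so the group on this nitrogen still strongly shapes the result when the hydrogen on that nitrogen stays in place. Compound 2 had already bound strongly, yet this position turns out to accept a larger group with a hetero atom in the ring and hydrogen-bond acceptors that cyclohexyl lacks, and the number falls further rather than rising. The compounds shown offer no measured property that would explain this gain.

On these data alone, the change replaces the ring and adds the ethoxycarbonyl group in a single step, so it remains open how much of the gain belongs to the ring nitrogen and how much to the carbamate. A plain piperidin-4-yl with a free amine would separate those two parts, while a methoxycarbonyl, a butoxycarbonyl with its longer chain, or an acetyl on the ring nitrogen would show how closely the ethoxycarbonyl group itself is tied to the result.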